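A few compounds are considered here, and "the series" means these few. Any claim that something is new, unique, unknown or untested is made for them only; others in the source may bear on it.

In a physicochemical assay for solubility (a lower number here means a less soluble compound, a higher number a more soluble compound), compound 2 (`CC(C)Oc1ccc(S(C)(=O)=O)cc1C(=O)N1Cc2cc(C(F)(F)F)cnc2C1`) gives 114 ug/mL. That value lies within the scatter of compound 3 (`CC(C)Oc1ccc(S(C)(=O)=O)cc1C(=O)N1Cc2ccc(C3CCOCC3)cc2C1`) at 191 ug/mL. The gap to compound 1 (`C[C@H](Oc1ccc(S(C)(=O)=O)cc1C(=O)N1Cc2ccc(-c3ccccn3)cc2C1)C(F)(F)F`) at 30 ug/mL lies beyond the scatter, with compound 2 on the more soluble side.

The next compound to be measured is compound 4 (`CS(=O)(=O)c1ccc(-c2ccc(F)c(F)c2)c(C(=O)N2Cc3cc(C(F)(F)F)cnc3C2)c1`), which keeps the shared core of compound 2 and has 3,4-difluorophenyl in place of isopropoxy on an aromatic carbon, para to a methylsulfonyl group: 3,4-difluorophenyl in place of isopropoxy on an aromatic carbon.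

For the measured compounds named here, no pair of measured compounds differs in one place only, so the size of this change has no direct precedent. The nearest guide is compound 1 at 30 ug/mL, which also carries an extra aromatic ring, although elsewhere on its structure. On that weak basis, a fall beyond the scatter is expected, and the expected step is a 4.6-fold lower number from compound 2 to compound 4 (0.66 log units; beyond the scatter).

For compound 4 the estimated value is 25 ug/mL, with an expected range of 6 ug/mL to 85 ug/mL.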

Compound 4, solubility: 42 ug/mL
The estimate for compound 4 lay 1.7-fold (0.23 log units) below the measured number; low and high end bracket the measured number.
By their numbers in this assay, from the lowest: compounds 1 and 4 (each within the scatter of the next); then compounds 2 and 3 (each within the scatter of the next).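

In this assay, the position para to a methylsulfonyl group now has its first single-change reading: 3,4-difluorophenyl in place of isopropoxy gives a 2.7-fold lower number from compound 2 to compound 4 (0.43 log units; beyond the scatter) and leaves the rest of compound 2 intact. The step lies beyond the scatter but is modest in size, so this position does respond to the exchange of a ring-free ether for an aromatic ring. No measurement shown bears on the cause of this step.

The compounds shown leave open how an amine, a carboxylic acid or a longer alkoxy chain at this position would read in this assay. They also leave open whether the same exchange would give a step of similar size on the cores of compound 1 or compound 3.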